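Aryl swap on a thiophene amino ester: from fluoro to nitrile

A few compounds are considered here, and "the series" means these few. Any claim that something is new, unique, unknown or untested is made for them only; others in the source may bear on it.

Compound 1 `COc1cccc(-c2csc(N)c2C(=O)OCc2ccccc2)c1`: 57%
Compound 2 `Nc1scc(-c2ccccc2F)c1C(=O)OCc1ccccc1`: 57%
Compound 3 `N#Cc1cccc(-c2csc(N)c2C(=O)OCc2ccccc2)c1`: to be measured

In an assay on isolated protein for inhibition of protein kinase C zeta type (Homo sapiens), with stated times of 1 h and 2.5 min, tested at 30 uM (a higher number here means more inhibition at the concentration tested (going by the name of the read-out), a lower number less inhibition), compound 2 stands level with compound 1, the step of no change at the digits printed from compound 1 to compound 2 (within the scatter) lying within the scatter. Compound 3 `N#Cc1cccc(-c2csc(N)c2C(=O)OCc2ccccc2)c1` carries a further change at the same place: 3-cyanophenyl in place of 2-fluorophenyl on an aromatic carbon. Within the data shown here, the only step that bears on it is the aryl swap from compound 1 to compound 2, which brought no change; an exchange of one substituted phenyl for another is therefore expected to leave this assay where it is, with the step of a number 2 percentage points lower from compound 2 to compound 3 (within the scatter) estimated within the scatter. Compound 3 is estimated at 55%, in the range 35% to 75%.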

Compound 3, a percentage reported as inhibition, at one concentration (the size of the read-out at that concentration, not a potency): 25%
Compound 3: the middle estimate sits 30 percentage points above what was measured, outside the stated range (below it).
By their numbers in this assay, from the lowest: compound 3; then compounds 1 and 2 (each within the scatter of the next).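

In this assay the aryl group on the shared core proves sensitive to what it carries: the earlier swap gave no change at the digits printed from compound 1 to compound 2 (within the scatter), but 3-cyanophenyl in place of 2-fluorophenyl gives a number 32 percentage points lower from compound 2 to compound 3 (beyond the scatter), and cyano in place of methoxy gives a number 32 percentage points lower from compound 1 to compound 3 (beyond the scatter). The second comparison keeps the substituent's place on the phenyl ring, so the identity of that group alone can separate these compounds. Nothing available accounts for the drop.

As far as these compounds go, it remains open whether an amine or a carboxylic acid in place of the nitrile would stay level with compound 1 or fall like compound 3. A 2-cyanophenyl group would show whether the nitrile's effect persists when its place on the phenyl ring changes.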